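The compounds below may be only part of what the source reports. "The series", "measured", "known", "first", "only" and "open" are said of these compounds alone.

In a toxicity assay on MT4 cells (Homo sapiens) for cytotoxicity, read by MTT assay, with a stated time of 5 days (a higher number here means that more compound is tolerated, a lower number that less compound is tolerated), compound 1 `CC(=O)Nc1ccc(OCc2nnc(SCC(=O)Nc3ccc(Br)cc3)n2Cc2ccccc2)cc1` is reported only as a limit, >= 3.99 ug/mL. Compound 2 `CC(=O)Nc1ccc(OCc2nnc(SCC(=O)Nc3ccc([N+](=O)[O-])cc3)n2Cc2ccccc2)cc1` gives 105 ug/mL in this assay, and compound 3 `O=C(CSc1nnc(COc2ccc3ccccc3c2)n1Cc1ccccc1)Nc1ccc(Br)cc1` gives 58.1 ug/mL; compound 2 and compound 3 lie within the usual scatter of each other. The change from compound 1 to compound 2 is nitro in place of bromo on an aromatic carbon, and its step, a step that the limit leaves unreadable from compound 1 to compound 2, cannot be sized. The cores of compound 1 and compound 3 differ by naphthalen-2-yl in place of 4-acetamidophenyl on an oxygen on a saturated carbon, and that step, a step that the limit leaves unreadable from compound 1 to compound 3, cannot be sized either. Compound 4 `O=C(CSc1nnc(COc2ccc3ccccc3c2)n1Cc1ccccc1)Nc1ccc([N+](=O)[O-])cc1` carries the same change as compound 2, (nitro in place of bromo on an aromatic carbon), at the same place. Because compound 1 sits at the limit (the limit of >= 3.99 ug/mL in this assay, at which 1 of the 3 values shown sits), the earlier step offers no size to lean on, so the step from compound 3 to compound 4 in this assay is expected to be small, a 1.2-fold higher number from compound 3 to compound 4 (0.08 log units; within the scatter). Compound 4 is estimated at 70 ug/mL, expected between 30 ug/mL and 160 ug/mL.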

Compound 4, half-maximal cytotoxic concentration: >= 116 ug/mL
Compound 4 ended at the assay's limit; the forecaster's own chance of this, stated with the estimate: 10%; middle value at least 1.6-fold (0.21 log units) from the limit.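

In this assay, nitro in place of bromo on the core of compound 3 gives an at least 1.9-fold higher number from compound 3 to compound 4 (0.30 log units; that floor lies within the scatter), and naphthalen-2-yl in place of 4-acetamidophenyl on the nitro side gives an at least 1.1-fold higher number from compound 2 to compound 4 (0.04 log units; that floor lies within the scatter). Compound 4 is reported only as a limit: the limit of >= 116 ug/mL in this assay, at which 1 of the 4 values shown sits. Both steps from compound 1 cannot be read, so the series does not show whether the nitro change has the same size on the two cores, only that neither floor goes beyond the scatter: the limit of >= 3.99 ug/mL in this assay, at which 1 of the 4 values shown sits.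

The compounds shown leave open how the number would move with an amine or a carboxylic acid in the place of the nitro. They also leave open whether a methoxy group there would behave like bromo or like nitro on either core.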